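The source may report more compounds than this note shows. Statements on the series, on what has been measured and on what is new or still open speak of the compounds shown alone.

Of the compounds shown here, three built on one shared core have been tested in a functional assay on KG-1a cells (Homo sapiens) for inhibition, read by MTT assay, with a stated time of 72 h; on this read-out higher numbers stand for weaker inhibition and lower numbers for stronger inhibition. Compound 1, with the structure `Cc1ccc(-c2cn(-c3ccc(CN4CCCC4)cc3)nn2)cc1Nc1nccc(-c2cccnc2)n1`, gives 5420 nM in this assay. Compound 2, with the structure `Cc1ccc(-n2cc(-c3cc(C(F)(F)F)cc(C(F)(F)F)c3)nn2)cc1Nc1nccc(-c2cccnc2)n1`, gives 9930 nM in this assay. Both numbers sit in the weak range of the read-out, and the gap between them is not large.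

Compound 3, with the structure `Cc1ccc(-n2cc(-c3ccc(C)c(C(F)(F)F)c3)nn2)cc1Nc1nccc(-c2cccnc2)n1`, reaches only a limit of the assay in this assay, recorded as > 30000 nM. This is the limit of > 30000 nM in this assay, at which 1 of the 3 values shown sits, so for compound 3 there is no measured number, only the statement that inhibition was too weak to be quantified within the range of the test. Compound 3 therefore stands at the weak edge of what this assay can report.

Compound 4, with the structure `Cc1ccc(-n2cc(CCO)nn2)cc1Nc1nccc(-c2cccnc2)n1`, is the next compound to be measured. Its relation to compound 3 is 2-hydroxyethyl in place of 4-methyl-3-(trifluoromethyl)phenyl on an aromatic carbon. For the measured compounds named here, no pair of measured compounds differs in exactly this way, so there is no measured step to lean on. Given that compound 3 sits at a limit, no step beyond the usual scatter is expected from compound 3 to compound 4 in this assay, and the expected change is an at least 1.5-fold lower number from compound 3 to compound 4 (0.17 log units; that floor lies within the scatter). Compound 4 is estimated at 20000 nM, with a range from 6000 nM to 60000 nM.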

Compound 4, half-maximal inhibitory concentration: 6540 nM
For compound 4 the middle estimate is 3.1-fold (0.49 log units) above the measured one, and the stated range covers the measured number.
By their numbers in this assay, from the lowest: compounds 1, 4 and 2 (each within the scatter of the next). At a limit, above all of these: compound 3.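

For the compounds shown here, on the aromatic carbon of the five-membered aromatic ring with 3 nitrogen, the first step that can be read at this position comes in this assay: putting 2-hydroxyethyl in place of 4-methyl-3-(trifluoromethyl)phenyl gives an at least 4.5-fold lower number from compound 3 to compound 4 (0.66 log units; beyond the scatter). This shows that the position does not need a carbon-only aromatic ring to give a measurable number, since compound 4 carries a short chain with no ring there and gives 6540 nM, a number that still sits in the weak range of the read-out. On these data alone, the step is only a floor and its true size is unknown, because compound 3 has a limit and not a number: the limit of > 30000 nM in this assay, at which 1 of the 4 values shown sits.

The change removes the ring and brings in the hydroxyl group at the same time, so the compounds shown cannot tell which of the two accounts for the step. A plain ethyl chain on the same carbon would separate those two parts, while a longer chain ending in hydroxyl, an amine or a carboxylic acid there would show whether this position can give a clearly lower number.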